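Chloro in Place of Amino on Two Bicyclic Cores

This account rests on a few compounds, and the source may have more. Where it says the series, first, only, none or still open, it means among the compounds named here.

Measured so far:
compound 1, `Nc1nc(Cl)c2nnn([C@H]3CCCC[C@H]3CO)c2n1`, 95500 nM
compound 2, `Nc1nc(N)c2nnn([C@H]3CCCC[C@H]3CO)c2n1`, > 200000 nM
compound 3, `Nc1ncnc2c1ncn2[C@@H]1C[C@@H]2COC[C@H]2[C@H]1CO`, > 200000 nM

Compounds 1 and 2 share one core, compound 3 carries another, and how the two cores differ is not broken down here. In an ADME assay on L1210/0 cells (Mus musculus) for cytotoxicity, with a stated time of 48 h (a lower number here means a stronger inhibitor, a higher number a weaker inhibitor), compound 1 gives 95500 nM. In this assay compound 2 gives > 200000 nM, which is a limit of the assay. Compound 3 gives > 200000 nM in this assay, again a limit of the assay. For the measured compounds named here, the one counted change between measured compounds is chloro in place of amino on an aromatic carbon, and it made an at least 2.0-fold lower number from compound 2 to compound 1 (0.32 log units; beyond the scatter). Compound 4, `OC[C@@H]1[C@@H]2COC[C@H]2C[C@H]1n1cnc2c(Cl)ncnc21`, has not yet been measured; it differs from compound 3 by chloro in place of amino on an aromatic carbon, the same kind of change, though in compound 2 the place is also meta to an amino group (1 heavy atom), which compound 3 lacks. Two of three values shown sit at the limit of > 200000 nM in this assay, at which 2 of the 3 values shown sit. Since compound 3 is a limit, compound 4 is expected to show an at least 2.0-fold lower number from compound 3 to compound 4 (0.30 log units; that floor lies within the scatter), by analogy with an at least 2.0-fold lower number from compound 2 to compound 1 (0.32 log units; beyond the scatter). Compound 4 is estimated at 100000 nM, between 40000 nM and 200000 nM.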

Compound 4, half-maximal inhibitory concentration: > 200000 nM
Compound 4 ended at the assay's limit; the forecaster's own chance of this, stated with the estimate: 35%; middle value at least 2.0-fold (0.30 log units) away from the limit.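

The step between compound 3 and compound 4, chloro in place of amino on an aromatic carbon, cannot be read, as both values are limits in this assay: the limit of > 200000 nM in this assay, at which 3 of the 4 values shown sit.

The compounds shown leave open whether this change lowers the number on the core of compound 3 as it does on the core of compound 1.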